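The compounds below may be only part of what the source reports. "The series", "measured", "known", "first", "only" and "open" are said of these compounds alone.

In a functional assay on ECa-109 cells (Homo sapiens) for inhibition, read by MTT assay, with a stated time of 72 h (on this read-out higher numbers stand for weaker inhibition and lower numbers for stronger inhibition), the three measured compounds lie close together. Compound 1 `CC(C)(C)OC(=O)N1CCN(C(=S)SCc2cn(-c3ccccc3F)nn2)CC1` gives only a limit of the assay, > 128000 nM. Compound 2 `COc1ccc(Cn2cc(CSC(=S)N3CCN(C(=O)OC(C)(C)C)CC3)nn2)cc1` gives 36800 nM, and compound 3 `O=C(OCc1ccccc1)N1CCN(C(=S)SCc2cn(Cc3ccccc3Cl)nn2)CC1` gives 56800 nM, the highest of the two numbers shown; its gap to compound 2 is within the scatter, so the two cannot be ordered. For the measured compounds named here, the one measured step, an at least 3.4-fold lower number from compound 1 to compound 2 (0.54 log units; beyond the scatter), concerns the group on the aromatic nitrogen and starts from a limit of > 128000 nM in this assay, at which 1 of the 3 values shown sits, rather than a number.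

Compound 4 `CC(C)(C)OC(=O)N1CCN(C(=S)SCc2cn(Cc3ccccc3Cl)nn2)CC1` differs from compound 3 by tert-butyl in place of benzyl on an oxygen next to a carbonyl group. Going by the values given here, no measured pair differs at this oxygen alone: compound 2 already carries the tert-butoxycarbonyl group, but with 4-methoxybenzyl on the aromatic nitrogen, so its value set against that of compound 3 mixes two changes and settles nothing about the carbamate. The measured step therefore has no bearing on the change in hand. The expectation for this assay is accordingly a step of no more than the scatter, in no decided direction, and a 1.1-fold lower number from compound 3 to compound 4 (0.06 log units; within the scatter) is what is expected. Compound 4 is estimated at 50000 nM, with a range from 15000 nM to 150000 nM.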

Compound 4, half-maximal inhibitory concentration: 11900 nM
For compound 4 the middle estimate is 4.2-fold (0.62 log units) above the measured one; measured number outside the range, below it.
By their numbers in this assay, from the lowest: compound 4; then compounds 2 and 3 (each within the scatter of the next). At a limit, above all of these: compound 1.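

In this assay, the oxygen next to a carbonyl group now has a pair that differs there alone, and the change is not neutral: a 4.8-fold lower number from compound 3 to compound 4 (0.68 log units; beyond the scatter) with tert-butyl in place of benzyl and the 2-chlorobenzyl group held fixed. With the tert-butoxycarbonyl group held fixed instead, the group on the saturated chain carbon bound to the aromatic nitrogen also registers, since 2-chlorophenyl in place of 4-methoxyphenyl gives a 3.1-fold lower number from compound 2 to compound 4 (0.49 log units; beyond the scatter). The change from 2-fluorophenyl to 2-chlorobenzyl on the aromatic nitrogen gives an at least 10-fold lower number from compound 1 to compound 4 (1.03 log units; beyond the scatter), but that step starts from a limit and not a number, so its true size stays unknown: the limit of > 128000 nM in this assay, at which 1 of the 4 values shown sits.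

The compounds shown leave open whether the step at the oxygen keeps its size and direction with 4-methoxybenzyl on the aromatic nitrogen, as only one pair reads this change. They also leave open how methyl, a longer chain or a carbamate carrying an amine would read at that oxygen, set against tert-butyl.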